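Changing the anilide ring while keeping the benzyl group

A few compounds are considered here, and "the series" means these few. Any claim that something is new, unique, unknown or untested is made for them only; others in the source may bear on it.

Three compounds share one core and differ at two places. Compound 1 `Cc1ccc(NC(=O)CN2CCN(c3nnc(Cc4ccccc4)c4ccccc34)CC2)c(C)c1` carries a phenyl on the saturated chain carbon and a 2,4-dimethylphenyl on the amide nitrogen; in a functional assay on MDA-MB-231 cells (Homo sapiens) for cytotoxicity, read by MTT assay, with a stated time of 72 h (a lower number here means a stronger inhibitor, a higher number a weaker inhibitor), compound 1 gives 181000 nM, the highest of the three numbers. Compound 3 `Cc1ccc(NC(=O)CN2CCN(c3nnc(Cc4ccncc4)c4ccccc34)CC2)c(C)c1` gives 240 nM and compound 2 `Cc1ccccc1NC(=O)CN1CCN(c2nnc(Cc3ccncc3)c3ccccc23)CC1` gives 200 nM, so compound 1 stands far apart from both, as the step of a 750-fold lower number from compound 1 to compound 3 (2.88 log units; beyond the scatter) shows.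

Compound 4 `O=C(CN1CCN(c2nnc(Cc3ccccc3)c3ccccc23)CC1)Nc1c(F)cccc1F` keeps the phenyl of compound 1 and alters only the amide side: 2,6-difluorophenyl in place of 2,4-dimethylphenyl on an amide-type nitrogen. Going by the values given here, no measured step tests this exact exchange. Among the compounds with values here, the only change made on that ring among the measured compounds, a 1.2-fold higher number from compound 2 to compound 3 (0.08 log units; within the scatter), was small, which suggests that substituents on the anilide ring shift the number little, whereas the large step from compound 1 to compound 3 arose elsewhere. Compound 4 is therefore expected to remain close to compound 1, with a 1.2-fold lower number from compound 1 to compound 4 (0.08 log units; within the scatter) judged to lie within the scatter. The estimate for compound 4 in this assay is 150000 nM, with a range from 40000 nM to 500000 nM, and a real chance that only a limit is reported.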

Compound 4, half-maximal inhibitory concentration: 5490 nM
The estimate for compound 4 lay 27-fold (1.44 log units) above the measured number, outside the stated range (below it).
By their numbers in this assay, from the lowest: compounds 2 and 3 (each within the scatter of the next); then compound 4; then compound 1.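

The amide side of the core is not a silent position: in this assay, with the phenyl kept on the saturated chain carbon, exchanging 2,4-dimethylphenyl for 2,6-difluorophenyl on the amide-type nitrogen gives a 33-fold lower number from compound 1 to compound 4 (1.52 log units; beyond the scatter). Going by these compounds alone, the one earlier change on this ring, a 1.2-fold higher number from compound 2 to compound 3 (0.08 log units; within the scatter), was a methyl in place of hydrogen with pyridin-4-yl on the chain carbon, so its lack of effect does not carry over to this exchange, even though the two groups leaving and entering here match in heavy atoms, ring type and counted donors and acceptors. Nothing at hand gives a measured property of either group that could account for the step.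

The compounds shown leave open whether the same exchange would move the number at all with pyridin-4-yl on the chain carbon, where the values already stand far lower. They also leave open whether the step follows the change from methyl to fluorine or the change in substitution pattern, which a 2,4-difluorophenyl or a 2,6-dimethylphenyl on that nitrogen would separate.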